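This account rests on a few compounds, and the source may have more. Where it says the series, first, only, none or still open, it means among the compounds named here.

Three compounds have so far been measured in a functional assay on RAW264.7 cells (Mus musculus) for inhibition, with a stated time of 4 days; a lower number here means a stronger inhibitor, a higher number a weaker inhibitor:

Compound 1 `COc1cc(/C=C/C(=O)c2cccc(N=[N+]=[N-])c2)ccc1O` gives 7110 nM.
Compound 2 `COc1ccc(/C=C/C(=O)c2cccc(N=[N+]=[N-])c2)cc1O` gives 1960 nM.
Compound 3 `C=C(C)c1cn(-c2cccc(C(=O)/C=C/c3ccc(O)c(OC)c3)c2)nn1` gives 9790 nM.

Compound 3 stands with the highest number of the three. Its nearest neighbour is compound 1: the step of a 1.4-fold higher number from compound 1 to compound 3 (0.14 log units; within the scatter) lies within the scatter, so the two cannot be told apart. Compound 2 gives a lower number than compound 3, and that gap lies beyond the scatter.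

Compound 4 `COc1cc(/C=C/C(=O)c2cccc(-n3cc(-c4ccc(C)cc4)nn3)c2)ccc1O` keeps the whole of compound 3 except for one exchange: 4-methylphenyl in place of 1-methylethenyl on an aromatic carbon. Among the measured compounds shown here, the only measured step that touches this part of the molecule is a 1.4-fold higher number from compound 1 to compound 3 (0.14 log units; within the scatter), where putting the whole triazole in for azido changed little. For the measured compounds named here, no measured step exchanges one group for another on that triazole, so nothing shows whether a larger ring group will help or hurt. The expectation is therefore a step close to the scatter, a 1.4-fold lower number from compound 3 to compound 4 (0.15 log units; within the scatter), with wide uncertainty in either direction. Compound 4 is estimated at 7000 nM, with a range from 2000 nM to 25000 nM.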

Compound 4, half-maximal inhibitory concentration: 15400 nM
The estimate for compound 4 lay 2.2-fold (0.34 log units) below the measured number; low and high end bracket the measured number.
By their numbers in this assay, from the lowest: compound 2; then compounds 1, 3 and 4 (each within the scatter of the next, the first and the last beyond it).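

Among the compounds shown here, this is the first exchange of one group for another on the five-membered aromatic ring with 3 nitrogen, and in this assay it gives a 1.6-fold higher number from compound 3 to compound 4 (0.20 log units; within the scatter). Going from 1-methylethenyl, with 3 heavy atoms and no ring, to 4-methylphenyl, with 7 heavy atoms and a six-membered aromatic ring, therefore makes no difference that can be told from repeat scatter, so for these two groups the added size and the added ring leave the number effectively unchanged. No measurement at hand offers an explanation for this result.

Going by these compounds, both groups contain carbon only and have no hydrogen-bond donors or acceptors, so the effect of an amine or a carboxylic acid at this position remains open. On these data alone, a longer chain, such as n-butyl, also remains untested here.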